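The compounds below may be only part of what the source reports. "The series", "measured", "known", "first", "only" and "open" are said of these compounds alone.

Compound 1 `C=CCOc1cc(C2=C(c3cc(OC)c(OC)c(OC)c3)C(=O)C(O)C2)ccc1OC` was tested in an ADME assay on HT-29 cells (Homo sapiens) for cytotoxicity, read by MTT assay, with a stated time of 72 h; a higher number here means a weaker inhibitor, a lower number a stronger inhibitor. Its result, > 100 ug/mL, is a limit of the assay rather than a number, so compound 1 sits at the limit of > 100 ug/mL in this assay, at which 1 of the 2 values shown sits. Compound 2 `COc1ccc(C2=C(c3cc(OC)c(OC)c(OC)c3)C(=O)CC2OC(C)=O)cc1NC=O` gives < 1 ug/mL in this assay, again a limit, at the limit of < 1 ug/mL in this assay, at which 1 of the 2 values shown sits. Compound 3 `COc1ccc(C2=C(c3cc(OC)c(OC)c(OC)c3)C(=O)C(O)C2)cc1F` has not been measured; it differs from compound 1 by fluoro in place of allyloxy on an aromatic carbon. Going by the values given here, no measured pair shows this change, so the size of the step is open. For compound 3 a move toward stronger inhibition is expected, an at least 10-fold lower number from compound 1 to compound 3 (1.00 log units; beyond the scatter), giving an estimate of 10 ug/mL, between 1 ug/mL and 100 ug/mL.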

Compound 3, half-maximal inhibitory concentration: < 1 ug/mL
Compound 3: no number, only a limit; the forecaster's own chance of this, stated with the estimate: 30%; at least 10-fold (1.00 log units) between middle value and limit.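

In this assay, the aromatic carbon ortho to a methoxy group turns out to matter greatly: fluoro in place of allyloxy gives an at least 100-fold lower number from compound 1 to compound 3 (2.00 log units; beyond the scatter). Going by these compounds alone, the earlier compounds offered no comparison in one place, so this is the first measured step at this position. Compound 3 has only a limit of the assay, so its true strength stays unknown: the limit of < 1 ug/mL in this assay, at which 2 of the 3 values shown sit.

From the compounds shown here alone, whether fluoro itself matters, or simply the loss of allyloxy, stays open. Chloro or an amine at this carbon would help to separate the two.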